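Trimming a Methoxy Group from a Hydroxyphenyl Fragment

The compounds below may be only part of what the source reports. "The series", "measured", "known", "first", "only" and "open" are said of these compounds alone.

In a functional assay on K562 cells (Homo sapiens) for antiproliferative activity, read by resazurin assay, with a stated time of 72 h (on this read-out lower numbers stand for stronger inhibition and higher numbers for weaker inhibition), compound 1 `N#Cc1c(-c2cccs2)nc2c(c(-c3ccccc3)nn2-c2ccccc2)c1-c1ccc(O)cc1` gives 11600 nM. Compound 2 `COc1cc(-c2c(C#N)c(-c3ccccc3)nc3c2c(-c2ccccc2)nn3-c2ccccc2)ccc1O` reaches only the limit of this assay, > 50000 nM, so its true potency is not known as a number. It is therefore one of the values at the limit of > 50000 nM in this assay, at which 1 of the 2 values shown sits. Compound 3 `N#Cc1c(-c2ccccc2)nc2c(c(-c3ccccc3)nn2-c2ccccc2)c1-c1ccc(O)cc1` has not yet been tested. It differs from compound 2 in one spot: hydrogen in place of methoxy on an aromatic carbon. Among the measured compounds shown here, no measured pair shows this change on its own, so the size of the step in this assay is uncertain. A smaller number for compound 3 than the limit seen for compound 2 would count as a gain, yet the step could also stay within the usual scatter. Compound 3 is expected to reach 25000 nM, between 7000 nM and 80000 nM. The expected step is then an at least 2.0-fold lower number from compound 2 to compound 3 (0.30 log units; that floor lies within the scatter).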

Compound 3, half-maximal inhibitory concentration: 9600 nM
Beside the measured number, compound 3's estimate is 2.6-fold (0.42 log units) above it; low and high end bracket the measured number.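

In this assay, going from 4-hydroxy-3-methoxyphenyl to 4-hydroxyphenyl gives an at least 5.2-fold lower number from compound 2 to compound 3 (0.71 log units; beyond the scatter), so the methoxy on this aromatic carbon, ortho to a hydroxy group, now has a measured step attached to it. This step is only a floor, since compound 2 stands at a limit of the assay and not at a number: the limit of > 50000 nM in this assay, at which 1 of the 3 values shown sits. At the other site that changes, phenyl in place of thiophen-2-yl gives a 1.2-fold lower number from compound 1 to compound 3 (0.08 log units; within the scatter), so these two groups cannot be told apart in this read-out.

The compounds shown leave open how other groups on the same aromatic carbon would read, such as fluorine, an amine or an ethoxy group. Going by these compounds, all three compounds also keep the hydroxy group, so what happens when it is replaced by hydrogen or methoxy remains unknown.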